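Swapping a Basic Side Chain for a Cyclopentyl Ether

The source may hold more compounds than are shown below. What is called first, only, known or untested is meant among the compounds shown, and "the series" means these compounds.

Compound 1 `Cn1c(=O)c2[nH]c(-c3ccc(OCCC4CCNCC4)cc3)nc2n(C)c1=O` is one of two measured members of this small set. In an assay on CHO cells for binding affinity to adenosine receptor A2b (Homo sapiens), with a stated time of 20 min (on this read-out lower numbers stand for stronger inhibition and higher numbers for weaker inhibition), compound 1 gives 2.9 nM, the higher of the two numbers recorded. Compound 2 `Cn1c(=O)c2[nH]c(-c3ccc(OCCCN4CCN(Cc5ccccc5Cl)CC4)cc3)nc2n(C)c1=O`, which carries a longer chain ending in a substituted piperazine, gives 0.17 nM in this assay, a lower number, and the gap between the two lies beyond the usual scatter.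

Compound 3 `Cn1c(=O)c2[nH]c(-c3ccc(OC4CCCC4)cc3)nc2n(C)c1=O` has not yet been measured. It differs from compound 1 in one place: cyclopentyl in place of 2-(piperidin-4-yl)ethyl on an oxygen on an aromatic ring. The group that leaves brings one hydrogen-bond donor and one hydrogen-bond acceptor; the cyclopentyl that enters brings neither.

For the measured compounds named here, no measured pair shows this kind of change, so the expectation rests on compound 1 alone. The step from compound 1 to compound 3 is expected to move the number upward, toward weaker binding, by about a 4.1-fold higher number from compound 1 to compound 3 (0.62 log units; beyond the scatter). Compound 3 is therefore estimated at 12 nM in this assay, within a range from 2.5 nM to 60 nM.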

Compound 3, inhibition constant: 1 nM
Estimate against measurement, compound 3: 12-fold (1.08 log units) above; measured number outside the range, below it.
By their numbers in this assay, from the lowest: compound 2; then compound 3; then compound 1.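

In this assay, putting cyclopentyl in place of 2-(piperidin-4-yl)ethyl on the oxygen gives a 2.9-fold lower number from compound 1 to compound 3 (0.46 log units; beyond the scatter). This position therefore accepts a smaller group made of carbon only, with no hydrogen-bond donor or acceptor, and binding does not suffer. The piperidine ring and the chain that carries it are not needed for strong binding in this series, though nothing at hand explains why the number falls.

Going by these compounds, it remains open whether the gain comes from the cyclopentyl ring itself or simply from losing the piperidine, and a methyl or cyclohexyl group on the same oxygen would help separate the two. On these data alone, it is also open how a chain ending in a carboxylic acid would behave at this position.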